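Formyl in Place of Ethyl on a Shared Core

The compounds below may be only part of what the source reports. "The series", "measured", "known", "first", "only" and "open" are said of these compounds alone.

Of the compounds shown here, two built on one core have been measured. Compound 1 `COc1ccccc1-c1cn2ccnc2c(-c2ccc3ncn(C4CCCCC4)c3c2)n1` gives 8.4% in a functional assay on MCF7 cells (Homo sapiens) for inhibition, read by sulforhodamine B assay, with a stated time of 48 h, tested at 10 uM; a higher number here means more inhibition at the concentration tested (going by the name of the read-out), a lower number less inhibition. Compound 2 `CCc1ccc(-c2cn3ccnc3c(-c3ccc4ncn(Cc5ccccc5)c4c3)n2)cc1` gives 58% in this assay, the highest of the two numbers; its nearest neighbour is compound 1, whose value lies lower by a gap beyond the scatter. Compound 3 `O=Cc1ccc(-c2cn3ccnc3c(-c3ccc4ncn(Cc5ccccc5)c4c3)n2)cc1` differs from compound 2 by formyl in place of ethyl on an aromatic carbon. Within the data shown here, no step between measured compounds is known, so the size of this change is open; a moderate fall a number 13 percentage points lower from compound 2 to compound 3 (beyond the scatter) is expected in this assay. For compound 3 the expected value is 45%, between 15% and 75%.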

Compound 3, a percentage reported as inhibition, at one concentration (the size of the read-out at that concentration, not a potency): 47.8%
The estimate for compound 3 lay 2.8 percentage points below the measured number, and the stated range covers the measured number.
By their numbers in this assay, from the lowest: compound 1; then compound 3; then compound 2.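

Among these compounds, the change from 4-ethylphenyl to 4-formylphenyl gives the first step at a single place on this core, with a number 10.2 percentage points lower from compound 2 to compound 3 (beyond the scatter) in this assay and a size that counts as modest. At this position, para to a large group, formyl brings a hydrogen-bond acceptor that ethyl lacks, and the cost in inhibition is limited to that modest step. Nothing measured here explains the step.

Going by these compounds, whether the fall belongs to the carbonyl itself stays open, and a carboxylic acid, an aminomethyl group or a propyl chain at this position would bear on that. On these data alone, whether the step holds with a group other than benzyl on the core is also open.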